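Chalcone halogen swap: chloro to bromo on the phenol ring

A few compounds are considered here, and "the series" means these few. Any claim that something is new, unique, unknown or untested is made for them only; others in the source may bear on it.

Measured compounds:
compound 1 `COc1cc(Br)cc(/C=C/C(=O)c2ccccc2)c1O`, 40.7% in an ADME assay on MCF-10A cells (Homo sapiens) for cytotoxicity, read by sulforhodamine B assay, with a stated time of 72 h, tested at 30 uM; on this read-out lower numbers stand for a weaker effect and higher numbers for a stronger effect at the one concentration tested
compound 2 `COc1cccc(C(=O)/C=C/c2cc(Br)cc(OC)c2O)c1`, 47%
compound 3 `Cc1ccc(C(=O)/C=C/c2cc(Cl)ccc2O)cc1`, 51.1%

Compound 3 carries the largest number of the three. Against compound 2 the gap is small enough to sit within the usual scatter of repeated runs, so no order between those two can be read; against compound 1 the gap is wide enough to lie beyond the scatter. Going by the values given here, the one measured single-point step, methoxy in place of hydrogen on an aromatic carbon, gives a number 6.3 percentage points higher from compound 1 to compound 2 (within the scatter), and nothing turned on it.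

Compound 4 `Cc1ccc(C(=O)/C=C/c2cc(Br)ccc2O)cc1` is not yet measured. It differs from compound 3 by bromo in place of chloro on an aromatic carbon, the exchange sitting on an aromatic carbon of a six-membered aromatic ring of carbon only, meta to a large group and para to a hydroxy group. Among the compounds with values here, no measured step here exchanges one halogen for another, so no step bears on this change directly; the only measured step stayed within the scatter. On that footing no step beyond the scatter is expected, in either direction, for a number 0.1 percentage points lower from compound 3 to compound 4 (within the scatter).

Compound 4 is estimated at 51%, with a range from 38% to 63%.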

Compound 4, a percentage reported as activity, at one concentration (the size of the read-out at that concentration, not a potency): 49.4%
Beside the measured number, compound 4's estimate is 1.6 percentage points above it, within the range that was stated.
By their numbers in this assay, from the lowest: compounds 1, 2, 4 and 3 (each within the scatter of the next, the first and the last beyond it).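

In this assay, bromo in place of chloro, on an aromatic carbon meta to a large group and para to a hydroxy group, gives a number 1.7 percentage points lower from compound 3 to compound 4 (within the scatter), and this is the only halogen exchange among the compounds shown. Going by these compounds alone, at this position and at the one concentration tested, the two halogens cannot be told apart, so no order between compound 3 and compound 4 can be read, and the earlier compounds, which offered no such pair, could not show this. No measurement on hand offers any explanation for the result, and the read-out gives only the size of the effect at one concentration, not a potency.

From the compounds shown here alone, it remains open whether a group other than these two halogens on the same carbon, such as fluoro, an amine, a carboxylic acid or a longer chain, would also stay within the scatter of compound 3. Going by these compounds, it is equally open whether the same exchange would read alike on the core of compound 1 or of compound 2, where bromo shares its ring with a methoxy group.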